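The source may hold more compounds than are shown below. What is called first, only, known or untested is meant among the compounds shown, and "the series" means these compounds.

Compound 1 `O=C(/C=C/c1ccc(N2CCCC2)cc1)c1ccc([N+](=O)[O-])cc1` sits at the edge of what a functional assay on SNU-638 cells (Homo sapiens) for cytotoxicity, read by MTT assay (on this read-out lower numbers stand for stronger inhibition and higher numbers for weaker inhibition), can report: in this assay compound 1 gives only a limit, > 25000 nM, and no single number. That is the situation described by the limit of > 25000 nM in this assay, at which 1 of the 2 values shown sits. Compound 2 `COc1ccc(/C=C/C(=O)c2ccc(O)cc2)cc1Br` has no result in this assay, recorded as "not determined" (no result reported). Compound 3 `O=C(/C=C/c1ccc(N2CCCC2)cc1)c1ccc(F)cc1` differs from compound 1 in one place, (fluoro in place of nitro on an aromatic carbon). Among the measured compounds shown here, no measured step anchors this change, so the expected step that the limit leaves unreadable from compound 1 to compound 3 is small and may lie within the scatter. Compound 3 is therefore expected to fall near 30000 nM, in a range from 8000 nM to 100000 nM.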

Compound 3, half-maximal inhibitory concentration: > 25000 nM
Compound 3 was reported as a limit (the forecaster's own chance of this, stated with the estimate: 60%); the middle value does not contradict the limit.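

In this assay, among the compounds shown here, compound 1 and compound 3 both give only a limit, so no step between them can be read: the limit of > 25000 nM in this assay, at which 2 of the 3 values shown sit. From the compounds shown here alone, whether fluoro in place of nitro makes any difference to cytotoxicity remains open.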